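The source may hold more compounds than are shown below. What is called first, only, known or untested is meant among the compounds shown, and "the series" means these compounds.

Measured in a functional assay on cardiac atrium (Cavia porcellus); on this read-out higher numbers stand for an effect only at larger amounts of compound and lower numbers for an effect already at smaller amounts:
- compound 1 `COC(=O)C1=C(C)NC(C)=C(C(=O)OC)C1c1c(-c2ccccn2)nc2sccn12`: 24400 nM
- compound 2 `COC(=O)C1=C(C)NC(C)=C(C(=O)OC)C1c1c(-c2ccccn2)nc2sc(C)cn12`: 39900 nM
- compound 3 `COC(=O)C1=C(C)NC(C)=C(C(=O)OC)C1c1c(-c2ccncc2)nc2sc(C)cn12`: 7490 nM

Compound 1 lies within the scatter of compound 2, and compound 3 shows a lower number than either. Compound 4 `COC(=O)C1=C(C)NC(C)=C(C(=O)OC)C1c1c(-c2c(Cl)csc2Cl)nc2sccn12` keeps the core of compound 1 and changes one group: a group of 7 heavy atoms (4 carbon, 1 sulfur, 2 chlorine; one five-membered aromatic ring with 1 hetero atom) in place of a group of 6 heavy atoms (5 carbon, 1 nitrogen; one six-membered aromatic ring with 1 hetero atom), on an aromatic carbon. The closest evidence is a 5.3-fold lower number from compound 2 to compound 3 (0.73 log units; beyond the scatter), which came from exchanging one pyridinyl group for another at this place. The methyl change, a 1.6-fold higher number from compound 1 to compound 2 (0.21 log units; within the scatter), bears on it little. For the measured compounds named here, no measured compound has a five-membered aromatic ring here, so only a modest and uncertain move to a lower number is expected in this assay. The estimated change is a 2.0-fold lower number from compound 1 to compound 4 (0.31 log units; beyond the scatter). For compound 4 the expected value is 12000 nM, with an estimated range of 3000 nM to 45000 nM.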

Compound 4, half-maximal effective concentration: 2160 nM
The estimate for compound 4 lay 5.6-fold (0.74 log units) above the measured number, and the stated range ends above it.
By their numbers in this assay, from the lowest: compound 4; then compound 3; then compounds 1 and 2 (each within the scatter of the next).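

In this assay the step of an 11-fold lower number from compound 1 to compound 4 (1.05 log units; beyond the scatter) is large, so this aromatic carbon tolerates more than pyridinyl groups: a chlorine-bearing five-membered aromatic ring gives the lowest number of the four compounds. The pyridinyl exchange, a 5.3-fold lower number from compound 2 to compound 3 (0.73 log units; beyond the scatter), was only modest. Nothing measured here explains the step.

As far as these compounds go, it remains open how a thienyl group without chlorine or a plain phenyl group would read at this place. Also open, from the compounds shown here alone, is whether the same exchange would give a similar step on the methyl-bearing core of compound 2.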